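The compounds below may be only part of what the source reports. "The series", "measured", "known", "first", "only" and "open" are said of these compounds alone.

Two compounds of the series have numbers in a functional assay on SR cells (Homo sapiens) for cytotoxicity, read by sulforhodamine B assay, with a stated time of 48 h, tested at 0.1 uM; on this read-out higher numbers stand for a weaker effect at the one concentration tested and lower numbers for a stronger effect. Compound 1 `COc1cc(-c2cc(/C=C/C(=O)c3ccc(N)cc3)[nH]n2)cc(OC)c1OC` gives 87% there, and compound 2 `COc1ccc(-c2cc(/C=C/C(=O)c3ccc(N)cc3)[nH]n2)cc1OC` gives 104%. Compound 1 stands lowest of the two numbers; the nearest value lies a number 17 percentage points higher from compound 1 to compound 2 (beyond the scatter), a modest step and the only one measured so far. Compound 3 `COc1ccc(C(=O)/C=C/c2cc(-c3cc(OC)c(OC)c(OC)c3)n[nH]2)cc1` has not yet been measured. It differs from compound 1 by methoxy in place of amino on an aromatic carbon. Going by the values given here, no measured step bears directly on this change, since the single step known concerns hydrogen in place of methoxy on an aromatic carbon, not the group exchanged here, and it moved the number only modestly. For compound 3 the expected step is therefore small, a number 6 percentage points higher from compound 1 to compound 3 (within the scatter), without a firm direction beyond the scatter. The estimate for compound 3 is 93%, in a range from 72% to 112%.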

Compound 3, a percentage reported as activity, at one concentration (the size of the read-out at that concentration, not a potency): 83%
Beside the measured number, compound 3's estimate is 10 percentage points above it; measured number inside the range.
By their numbers in this assay, from the lowest: compounds 3 and 1 (each within the scatter of the next); then compound 2.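

Exchanging 4-aminophenyl for 4-methoxyphenyl on the core of compound 1 gives, in this assay, a number 4 percentage points lower from compound 1 to compound 3 (within the scatter), so this read-out does not separate amino from methoxy at this place on the ring. Going by these compounds alone, the hydrogen-bond donor counted for amino is absent from methoxy, yet the pair stays within the scatter, whereas the earlier a number 17 percentage points higher from compound 1 to compound 2 (beyond the scatter) remains the only step beyond it. No measurement at hand accounts for this result.

A single concentration cannot show whether compound 1 and compound 3 would also match in potency. On these data alone, it also remains open whether a larger or differently charged group at this place, such as a dimethylamino group, a carboxylic acid or a longer alkoxy chain, would keep the number within the scatter of compound 1.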